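Compound 1 to compound 3: removing the ring methyl

This account rests on a few compounds, and the source may have more. Where it says the series, first, only, none or still open, it means among the compounds named here.

Measured in a physicochemical assay for solubility, at pH 7.4; on this read-out lower numbers stand for lower solubility and higher numbers for higher solubility:
- compound 1 `CC1(c2nc(-c3ccc(CNC(=O)[C@H]4NCC[C@@H]4O)cc3)no2)CCCCC1`: > 50 ug/mL (a limit)
- compound 2 `CCCCCCCc1nc(-c2ccc([C@H](CC)NC(=O)[C@H]3NCC[C@@H]3O)cc2)no1`: 9 ug/mL

Compound 1 carries no exact number, only a limit of the assay: the limit of > 50 ug/mL in this assay, at which 1 of the 2 values shown sits. Compound 2 gives a true number, 9 ug/mL. Among the compounds with values here, no two measured compounds differ in one place, so no measured step bears on the change at hand.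

Compound 3 `O=C(NCc1ccc(-c2noc(C3CCCCC3)n2)cc1)[C@H]1NCC[C@@H]1O` keeps the rest of compound 1 and differs by hydrogen in place of methyl on a saturated ring carbon, or 1-methylcyclohexyl to cyclohexyl. Within the data shown here, with no measured step to guide it, no shift beyond the usual scatter is expected in this assay, and no direction is favoured. The expected size of the step that the limit leaves unreadable from compound 1 to compound 3 therefore stays within that scatter. Compound 3 is estimated at 60 ug/mL, with an expected range of 25 ug/mL to 150 ug/mL.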

Compound 3, solubility: > 50 ug/mL
Compound 3 ended at the assay's limit; the forecaster's own chance of this, stated with the estimate: 60%; the middle value does not contradict the limit.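

In this assay compound 1 and compound 3 both stand at a limit of the assay rather than at a number, so no step between them can be read: the limit of > 50 ug/mL in this assay, at which 2 of the 3 values shown sit.

The compounds shown leave open whether hydrogen in place of methyl on a saturated ring carbon changes this read-out at all.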